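This account rests on a few compounds, and the source may have more. Where it says the series, first, only, none or still open, it means among the compounds named here.

Compound 1, `OC[C@@]1(O)CO[C@@H](n2cnc3c(NCc4cccc(Cl)c4)ncnc32)[C@@H]1O`, stands at the top of the three numbers gathered so far. In an assay on CHO cells for displacement of a labelled ligand from adenosine receptor A3 (Homo sapiens), tested at 10 uM (on this read-out lower numbers stand for less inhibition and higher numbers for more inhibition at the one concentration tested (going by the name of the read-out)), compound 1 gives 43%. Compound 3, `Nc1ncnc2c1ncn2[C@H]1C[C@@H](CO)CO1`, is its nearest companion: in this assay compound 3 gives 31%, a gap beyond the usual scatter. Compound 2, `CCNC(=O)OC[C@@H]1CO[C@@H](n2cnc3c(N)ncnc32)[C@@H]1O`, lies furthest away: in this assay compound 2 gives 8%. The unmeasured compound 4, `OC[C@@]1(O)CO[C@@H](n2cnc3c(NCc4cccc(I)c4)ncnc32)[C@@H]1O`, keeps everything of compound 1 except one atom at the benzyl end: iodo in place of chloro on an aromatic carbon. For the measured compounds named here, no pair among the measured compounds differs in a single place, so there is no measured step to lean on. Swapping one halogen for another of the same kind is a small change in this context, and a step of modest size in either direction is expected, most likely upward; in this assay the step of a number 9 percentage points higher from compound 1 to compound 4 (within the scatter) is the estimate. Compound 4 is expected to give 52%, within a range from 28% to 76%.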

Compound 4, a percentage reported as inhibition, at one concentration (the size of the read-out at that concentration, not a potency): 48%
Estimate against measurement, compound 4: 4 percentage points above; measured number inside the range.
By their numbers in this assay, from the lowest: compound 2; then compound 3; then compounds 1 and 4 (each within the scatter of the next).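

For the compounds shown here, this is the first comparison here in which only one place differs. In this assay the swap of 3-chlorobenzyl for 3-iodobenzyl gives a number 5 percentage points higher from compound 1 to compound 4 (within the scatter) and so cannot be told apart from repeat measurements. On this carbon of the aromatic ring, iodo can therefore take the place of chloro with no clear change in the number, though nothing available explains why.

The compounds shown leave open whether bromo, methoxy, a nitrile or an amine at the same place would also leave the number level or would move it. Also open, from the compounds shown here alone, is whether a plain benzyl group, with only hydrogen at that place, would give a similar number, which would show whether a halogen is needed there at all.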